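The compounds below may be only part of what the source reports. "The series", "measured", "known", "first", "only" and "open" are said of these compounds alone.

Measured so far:
compound 1, `COc1ccc(C)cc1NC(=S)N/N=C/c1ccc2ccccc2n1`, > 100000 nM
compound 2, `Cc1cccc(NC(=S)N/N=C/c2ccc3ccccc3n2)c1`, > 100000 nM

In a functional assay on HT-29 cells (Homo sapiens) for antiproliferative activity, read by sulforhodamine B assay, with a stated time of 72 h (on this read-out higher numbers stand for weaker inhibition and lower numbers for stronger inhibition), compound 1 gives only a limit, > 100000 nM. Compound 2 likewise returns only a limit in this assay, > 100000 nM. Within the data shown here, the single step between them, a step that the two limits leave unreadable from compound 1 to compound 2, cannot be read: both values sit at the limit, (the limit of > 100000 nM in this assay, at which 2 of the 2 values shown sit). Compound 2 therefore stands at no point on a numerical scale; all that is known is that it sits at the limit.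

Compound 3, `NC(=S)N/N=C/c1ccc2ccccc2n1`, differs from compound 2 by hydrogen in place of 3-methylphenyl on an amide-type nitrogen. Among the measured compounds shown here, no measured step bears on this change: the one step concerns a substituent on the group that here leaves, and that step is itself unreadable. There is thus no basis for expecting a step in this assay in either direction beyond the scatter. Compound 3 is expected to remain at the limit, and the step of a number no higher from compound 2 to compound 3 (the limit leaves the size open) is estimated as no change. The estimate for compound 3 in this assay is 100000 nM, within 30000 nM to 300000 nM, with a limit rather than a number the most likely outcome.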

Compound 3, half-maximal inhibitory concentration: 100000 nM
The estimate for compound 3 equals the measured number at the digits printed, within the range that was stated.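

In this assay compound 3 gives 100000 nM, the first number rather than a limit in this series, with hydrogen in place of 3-methylphenyl on the amide-type nitrogen. Compound 2 gives > 100000 nM, which is a limit. The change therefore reads only as a number no higher from compound 2 to compound 3 (the limit leaves the size open), which shows that losing the 3-methylphenyl group from this nitrogen does not carry the value past what the aromatic compound shows, something the earlier, unreadable step on that group's substituent could not show.

Whether this step lies beyond the usual scatter cannot be read, and the series remains largely at the limit: the limit of > 100000 nM in this assay, at which 2 of the 3 values shown sit.

Also open, from the compounds shown here alone, is whether another group on this nitrogen, such as an ethyl chain, a morpholine ring or a chain ending in a carboxylic acid, would give a number clearly lower than that of compound 3.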